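This account rests on a few compounds, and the source may have more. Where it says the series, first, only, none or still open, it means among the compounds named here.

Three compounds have so far been measured in a functional assay on the whole organism (B cells) with Mus musculus as the target; a lower number here means a smaller maximal response, a higher number a larger maximal response:

Compound 1, `Nc1nc(O)c2c(n1)n(C1OC(CO)[C@@H](O)[C@H]1O)c(=O)n2CC(O)CSc1ccccc1`, gives 12%.
Compound 2, `CCCCCCCCCCn1c(=O)n(C2OC(CO)[C@@H](O)[C@H]2O)c2nc(N)nc(O)c21`, gives 0%.
Compound 3, `N#Cc1cccc(Cn2c(=O)n(C3OC(CO)[C@@H](O)[C@H]3O)c3nc(N)nc(O)c32)c1`, gives 16%.

Compound 3 stands highest of the three numbers in this assay. Its nearest neighbour is compound 1, which lies within the scatter of it, as a number 4 percentage points higher from compound 1 to compound 3 (within the scatter) shows; compound 2 is the furthest away, and the step of a number 16 percentage points higher from compound 2 to compound 3 (beyond the scatter) lies beyond the scatter. The same ordering appears in a number 12 percentage points lower from compound 1 to compound 2 (beyond the scatter).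

Compound 4, `CCCCn1c(=O)n(C2OC(CO)[C@@H](O)[C@H]2O)c2nc(N)nc(O)c21`, has not yet been measured. It differs from compound 3 in one place: propyl in place of 3-cyanophenyl on a saturated chain carbon bound to an aromatic nitrogen. The step that bears most directly on this change is a number 16 percentage points higher from compound 2 to compound 3 (beyond the scatter), where a plain alkyl chain on the saturated chain carbon bound to an aromatic nitrogen was exchanged for the 3-cyanophenyl group and the maximal response rose by a modest amount. For the measured compounds named here, compound 4 reverses that kind of exchange, though with propyl rather than nonyl, and there is no measured pair that separates one chain length from another. On that basis the step of a number 11 percentage points lower from compound 3 to compound 4 (beyond the scatter) is expected to be a modest drop in this assay. The maximal response of compound 4 is therefore estimated at 5%, with a range from 0% to 15%.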

Compound 4, largest response reached (reported as maximal response), in percent of the reference or control that the assay uses: 86%
Estimate against measurement, compound 4: 81 percentage points below; measured number outside the range, above it.
By their numbers in this assay, from the lowest: compound 2; then compounds 1 and 3 (each within the scatter of the next); then compound 4.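

In this assay, for the compounds shown here, the place on a saturated chain carbon bound to an aromatic nitrogen proves able to move the maximal response far more than the earlier compounds showed: with propyl entering there, the change is large both in the step of a number 70 percentage points higher from compound 3 to compound 4 (beyond the scatter) and in the step of a number 74 percentage points higher from compound 1 to compound 4 (beyond the scatter). The earlier compounds held only one plain alkyl chain, and it gave the lowest number, but the step of a number 86 percentage points higher from compound 2 to compound 4 (beyond the scatter), with hydrogen in place of hexyl, shows that among these compounds the length of the chain decides the response, not the mere presence of an alkyl group. Nothing measured here accounts for this rise.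

The compounds shown leave open how the response runs between the butyl chain of compound 4 and the longer chain of compound 2, and whether a shorter chain such as ethyl keeps it. They also leave open whether a plain benzyl group, or a butyl chain ending in an amine or a carboxylic acid, would hold the response or lose it.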